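The compounds below may be only part of what the source reports. "The series", "measured", "known", "first", "only" and "open" are said of these compounds alone.

Measured compounds:
compound 1, `Cc1ccc2ccn(CCN3CCCN(C)CC3)c2c1`, 125 nM in an assay on HEK293 cells for binding affinity to 5-hydroxytryptamine receptor 7 (Homo sapiens), read by radioligand binding; on this read-out lower numbers stand for stronger inhibition and higher numbers for weaker inhibition
compound 2, `CCc1ccc2ccn(CCN3CCCN(C)CC3)c2c1`, 166 nM in this assay
compound 3, `CC(C)CN1CCCN(CCn2ccc3ccc(Br)cc32)CC1`, 37 nM in this assay

Compound 1 and compound 2 share a core and differ only by methyl in place of hydrogen on a saturated chain carbon bound to an aromatic carbon. That step reads a 1.3-fold higher number from compound 1 to compound 2 (0.12 log units; within the scatter), so the two values are not told apart by this measurement. Compound 3 carries a different core from compound 1; the difference between the two cores is not broken down here. Compound 3 gives the lowest number of the three, and its gap to compound 1 and to compound 2 lies beyond the scatter in each case.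

Compound 4, `CC(C)(C)CN1CCCN(CCn2ccc3ccc(Br)cc32)CC1`, is not yet measured. It differs from compound 3 by methyl in place of hydrogen on a saturated chain carbon bound to three saturated chain carbons. This is the same kind of change as that from compound 1 to compound 2, but the place is not the same: there the entering methyl sits on a saturated chain carbon bound to an aromatic carbon, here on a saturated chain carbon bound to three saturated chain carbons. For the measured compounds named here, the one measured example of adding a methyl to a saturated chain carbon, from compound 1 to compound 2, stayed within the scatter, and on that basis the step from compound 3 to compound 4 is expected to be small as well, estimated as a 1.4-fold higher number from compound 3 to compound 4 (0.13 log units; within the scatter). Going by the values given here, because compound 3 stands at 37 nM, compound 4 is expected to give about 50 nM in this assay, with a likely range from 20 nM to 130 nM; the single precedent and the different surroundings of the place keep this estimate loose.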

Compound 4, inhibition constant: 163 nM
Beside the measured number, compound 4's estimate is 3.3-fold (0.51 log units) below it; measured number outside the range, above it.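

In this assay, replacing a hydrogen with a methyl on a saturated chain carbon bound to three saturated chain carbons, which turns isobutyl into neopentyl, gives a 4.4-fold higher number from compound 3 to compound 4 (0.64 log units; beyond the scatter) on the core of compound 3. Set beside the earlier methyl step, this change does not carry over at the same size from one core to the other: the same change on two cores in this assay, a 1.3-fold higher number (0.12 log units; within the scatter) from compound 1 to compound 2 and a 4.4-fold higher number (0.64 log units; beyond the scatter) from compound 3 to compound 4, 3.3-fold (0.52 log units) apart, beyond the scatter of two such steps

The two pairs differ in the place of the methyl as well as in the core, since the earlier methyl sits on a saturated chain carbon bound to an aromatic carbon, so these data cannot separate an effect of the core from an effect of the place, and with one pair on each core they give no rule for any further core in the series.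

Still open, as far as these compounds go, is how a longer chain, such as n-pentyl, or a cyclopropylmethyl group would read in place of the isobutyl of compound 3, which would show whether the higher number follows the branched neopentyl group specifically. Also open, from the compounds shown here alone, is how the isobutyl-to-neopentyl change itself would read on the core of compound 1, the direct test of whether the core or the place governs the size of this step.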